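Amide-bearing cyclobutyl replaces oxanyl on the aminonitrile core

A few compounds are considered here, and "the series" means these few. Any claim that something is new, unique, unknown or untested is made for them only; others in the source may bear on it.

The measured compounds and their values in an assay on isolated protein for inhibition of protein kinase C theta type (Homo sapiens), read by TR-FRET, with a stated time of 2 h (on this read-out lower numbers stand for stronger inhibition and higher numbers for weaker inhibition), are: compound 1, `N#Cc1cnc(NCc2cnccc2C(F)(F)F)cc1NC[C@H]1CC[C@@H](O)CC1`, with 58 nM; compound 2, `N#Cc1cnc(NCc2cnccc2C(F)(F)F)cc1NC1CCOCC1`, with 900 nM; and compound 3, `CC(C)(F)c1ncncc1CNc1cc(N[C@H]2CC[C@@H](O)CC2)c(C#N)cn1`, with 32 nM.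

Compound 2 holds the highest number of the three in this assay. Compound 1 stands nearest to it, and compound 3 stands furthest, both with lower numbers beyond the scatter. Going by the values given here, the only step that was measured in one place is a 16-fold higher number from compound 1 to compound 2 (1.19 log units; beyond the scatter), a large rise in the number when the oxan-4-yl group enters.

Compound 4, `CC1(C)[C@@H](Nc2cc(NCc3cnccc3C(F)(F)F)ncc2C#N)C[C@@H]1C(N)=O`, has not yet been measured. It differs from compound 2 by 3-carbamoyl-2,2-dimethylcyclobutyl in place of oxan-4-yl on a nitrogen on an aromatic ring. The step from compound 1 to compound 2 bears on this change only indirectly: it shows that the oxan-4-yl substituent at this nitrogen goes with the highest number seen here, and that a substituent carrying a hydrogen-bond donor at this nitrogen gave a much lower number. Among the compounds with values here, on that basis the expected step is a lowering of the number, a 7.5-fold lower number from compound 2 to compound 4 (0.88 log units; beyond the scatter), with wide uncertainty since no cyclobutyl compound was measured. Compound 4 is therefore estimated at 120 nM, within 30 nM to 500 nM.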

Compound 4, half-maximal inhibitory concentration: 1100 nM
Compound 4: middle estimate off by 9.2-fold (0.96 log units), on the low side; measured number above the stated range.
By their numbers in this assay, from the lowest: compounds 3 and 1 (each within the scatter of the next); then compounds 2 and 4 (each within the scatter of the next).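

At the position on a nitrogen on an aromatic ring, this assay does not separate 3-carbamoyl-2,2-dimethylcyclobutyl from oxan-4-yl: the change gives a 1.2-fold higher number from compound 2 to compound 4 (0.09 log units; within the scatter). A hydrogen-bond donor in the group at this nitrogen is therefore not enough on its own to give a low number, as 3-carbamoyl-2,2-dimethylcyclobutyl, which has one, still shows a 19-fold higher number from compound 1 to compound 4 (1.28 log units; beyond the scatter) when it stands in place of (4-hydroxycyclohexyl)methyl. No measurement at hand explains this result.

Still open, going by these compounds, is which part of the (4-hydroxycyclohexyl)methyl group goes with the lower number of compound 1, at 58 nM. The compounds shown also do not tell how a cyclobutyl group carrying a hydroxyl or an amine in place of the carbamoyl, or one without the dimethyl substitution, would read in this assay.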